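The source may report more compounds than this note shows. Statements on the series, on what has been measured and on what is new or still open speak of the compounds shown alone.

Measured so far:
Compound 1, `Cn1c(Cc2nn(C)c(=O)c3ccccc23)nnc1SCCCCCCCCCCCCCCCC(=O)Nc1ccc(Cl)cc1Cl`: 7300 nM
Compound 2, `CCCOc1ccc(NC(=O)CSc2nnc(Cc3nn(C)c(=O)c4ccccc34)n2C)cc1`: > 30000 nM

In an assay on isolated protein (Mus musculus) for inhibition of IL15-IL15 receptor (Homo sapiens), read by resazurin assay, with stated times of 30 min and 2.5 days (a higher number here means a weaker inhibitor, a lower number a stronger inhibitor), compound 1 gives 7300 nM. Compound 2 stands apart: in this assay compound 2 gives only a limit of the assay, > 30000 nM, not a number. This is the case described by the limit of > 30000 nM in this assay, at which 1 of the 2 values shown sits. Compound 3, `COc1ccc(NC(=O)CSc2nnc(Cc3nn(C)c(=O)c4ccccc34)n2C)cc1`, is not yet measured. It differs from compound 2 by hydrogen in place of ethyl on a saturated chain carbon bound to an oxygen on an aromatic ring — hydrogen in place of ethyl on a saturated chain carbon bound to an oxygen on an aromatic ring. Among the measured compounds shown here, no pair of measured compounds differs in one place only, so no measured step shows how such a change plays out in this assay. Given that compound 2 reaches only a limit in this assay, compound 3 is expected to behave much the same, with a step from compound 2 of a number no higher from compound 2 to compound 3 (the limit leaves the size open), nothing beyond the scatter. Compound 3 is therefore estimated at 30000 nM, in the range 10000 nM to 100000 nM, and most likely again only a limit.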

Compound 3, half-maximal inhibitory concentration: "not active" (no number reported)
No number was reported for compound 3, and the estimate cannot be compared.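

Among the compounds shown here, compound 3 is reported as not active, without a number, and compound 2 gives only a limit of the assay, so no step from one to the other can be read: the limit of > 30000 nM in this assay, at which 1 of the 3 values shown sits. The compounds shown leave open whether going from propoxy to methoxy changes inhibition at all in this assay.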